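Replacing a Distal Bromomethylphenyl Group with a Maleimide Chain

The source may hold more compounds than are shown below. What is called first, only, known or untested is meant among the compounds shown, and "the series" means these compounds.

Compound 1, `CCCn1c(=O)c2nc(-c3ccc(OCC(=O)NCCNS(=O)(=O)c4ccc(C)cc4)cc3)[nH]c2n(CCC)c1=O`, gives 72 nM in an assay on brain for binding affinity to adenosine receptor A1 (Rattus norvegicus), read by radioligand binding; on this read-out higher numbers stand for weaker inhibition and lower numbers for stronger inhibition.
Compound 2, `CCCn1c(=O)c2nc(-c3ccc(OCC(=O)NCCNC(=O)CBr)cc3)[nH]c2n(CCC)c1=O`, gives 17.6 nM in this assay.
Compound 3, `CCCn1c(=O)c2nc(-c3ccc(OCC(=O)NCCNC(=O)c4ccc(CBr)cc4)cc3)[nH]c2n(CCC)c1=O`, gives 11.5 nM in this assay.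

All three share a core and differ only in the group on the terminal amide nitrogen. Compound 3 has the lowest number of the three in this assay, though compound 2 sits within the scatter of it, so the two cannot be ordered; compound 1 lies clearly apart, with a 6.3-fold lower number from compound 1 to compound 3 (0.80 log units; beyond the scatter) and a 4.1-fold lower number from compound 1 to compound 2 (0.61 log units; beyond the scatter).

Compound 4, `CCCn1c(=O)c2nc(-c3ccc(OCC(=O)NCCNC(=O)CCCN4C(=O)C=CC4=O)cc3)[nH]c2n(CCC)c1=O`, takes the next step: a group of 10 heavy atoms (7 carbon, 1 nitrogen, 2 oxygen; one five-membered non-aromatic ring with 1 hetero atom) in place of a group of 8 heavy atoms (7 carbon, 1 bromine; one six-membered aromatic ring of carbon only), on a carbonyl carbon. The measured step that bears most directly on this position is a 1.5-fold lower number from compound 2 to compound 3 (0.18 log units; within the scatter), which shows that exchanging one group for another on that carbonyl carbon hardly moved the number. On that basis, a step within the scatter is expected in this assay, in either direction. Compound 4 is therefore estimated at 15 nM, with a range from 5 nM to 45 nM, an expected step of a 1.3-fold higher number from compound 3 to compound 4 (0.12 log units; within the scatter).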

Compound 4, inhibition constant: 37.8 nM
Compound 4: the middle estimate sits 2.5-fold (0.40 log units) below what was measured; the measured number falls inside the stated range.
By their numbers in this assay, from the lowest: compounds 3 and 2 (each within the scatter of the next); then compounds 4 and 1 (each within the scatter of the next).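

In this assay, the carbonyl carbon turns out to be less tolerant than the earlier exchange there suggested: the maleimide chain in place of 4-(bromomethyl)phenyl gives a 3.3-fold higher number from compound 3 to compound 4 (0.52 log units; beyond the scatter) and so separates the two groups, while replacing the bromine of compound 2 with the ring-bearing chain gives a 2.1-fold higher number from compound 2 to compound 4 (0.33 log units; beyond the scatter) in the same direction. The maleimide chain does not set compound 4 apart from the sulfonyl compound, with a 1.9-fold lower number from compound 1 to compound 4 (0.28 log units; within the scatter) leaving the two without an order. Nothing at hand explains these steps.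

The compounds shown leave open whether a longer chain carrying the same five-membered ring would change the number. They also leave open whether the bromine matters, as a plain 4-methylphenyl group on that carbonyl carbon would show.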